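Phenethyl to ((pyridin-2-yl)methyl)amino on a carbonyl carbon

The source may report more compounds than this note shows. Statements on the series, on what has been measured and on what is new or still open speak of the compounds shown alone.

Compound 1 `Cn1c(Cc2ccccc2C(F)(F)F)nc(C(=O)Nc2ccccc2)c(O)c1=O`: > 100000 nM
Compound 2 `Cn1c(Cc2ccccc2C(F)(F)F)nc(C(=O)CCc2ccccc2)c(O)c1=O`: > 100000 nM

Both entries come from an ADME assay on HepG2 cells (Homo sapiens) for cytotoxicity, in the presence of a further agent that is not named here; a lower number here means a stronger inhibitor, a higher number a weaker inhibitor. Compound 2 gives > 100000 nM, which is a limit and not a number. Compound 1 gives > 100000 nM, which is likewise a limit. Among the compounds with values here, the series so far therefore stands at the limit of > 100000 nM in this assay, at which 2 of the 2 values shown sit, and no actual potency has yet been read in this assay.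

Compound 3 `Cn1c(Cc2ccccc2C(F)(F)F)nc(C(=O)NCc2ccccn2)c(O)c1=O` has ((pyridin-2-yl)methyl)amino in place of phenethyl on a carbonyl carbon. Within the data shown here, only one measured step bears on this change, at the same carbonyl carbon: a step that the two limits leave unreadable from compound 1 to compound 2. It offers no size to carry forward. Compound 1 carries anilino at that place and still gives > 100000 nM, a limit. Neither group has moved the read-out off the limit, so no step beyond the scatter is expected, and a report of only a limit is likely.

The estimated step is a number no higher from compound 2 to compound 3 (the limit leaves the size open). For compound 3 the expected value is 100000 nM. The estimated range runs from 40000 nM to 150000 nM.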

Compound 3, half-maximal inhibitory concentration: > 100000 nM
Compound 3 gave a limit, no number; the forecaster's own chance of this, stated with the estimate: 85%; the middle value lies on the limit itself.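

In this assay compound 3 gives only a limit and not a number, so no new step can be read from compound 1 or compound 2 to compound 3. The series stands as follows: the limit of > 100000 nM in this assay, at which 3 of the 3 values shown sit. The compounds shown leave open whether the groups on the carbonyl carbon differ at all in this read-out.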